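A few compounds are considered here, and "the series" means these few. Any claim that something is new, unique, unknown or untested is made for them only; others in the source may bear on it.

Measured compounds in a functional assay on A-375 cells (Homo sapiens) for antiproliferative activity, read by MTT assay, with a stated time of 24 h; a lower number here means a stronger inhibitor, a higher number a weaker inhibitor:

- compound 1 `COc1cccc(C(=O)Oc2ccc3c(=O)c(-c4cc(OC)c(OC)cc4OC)coc3c2)c1`: > 10000 nM (a limit of this assay, not a number)
- compound 2 `COc1cc(OC)c(-c2coc3cc(OCc4ccc(F)cc4)ccc3c2=O)cc1OC`: 1720 nM
- compound 3 `COc1cc(OC)c(-c2coc3cc(OCc4ccccc4C)ccc3c2=O)cc1OC`: 1360 nM

Compound 1 stands only at a limit in this assay; its value is a bound and no number, so every step away from it can be given only as a lower bound. This is what the mark the limit of > 10000 nM in this assay, at which 1 of the 3 values shown sits, records.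

The next compound, compound 4 `COc1cc(OC)c(-c2coc3cc(OCc4cccc(Br)c4)ccc3c2=O)cc1OC`, differs from compound 1 in one place: 3-bromobenzyl in place of (3-methoxyphenyl)carbonyl on an oxygen on an aromatic ring.

For the measured compounds named here, two measured steps bear on this change, both exchanging the (3-methoxyphenyl)carbonyl for a substituted benzyl on the same oxygen: an at least 5.8-fold lower number from compound 1 to compound 2 (0.76 log units; beyond the scatter) and an at least 7.3-fold lower number from compound 1 to compound 3 (0.86 log units; beyond the scatter). The exchange of one substituted benzyl for another, a 1.3-fold lower number from compound 2 to compound 3 (0.10 log units; within the scatter), stays within the scatter, so the nature of the substituent on the benzyl ring has so far made no visible difference. A 3-bromobenzyl is expected to behave like its two measured relatives; the step from compound 1 to compound 4 is therefore expected to be a lowering of at least the size seen for compound 2 and compound 3, an at least 6.6-fold lower number from compound 1 to compound 4 (0.82 log units; beyond the scatter).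

Compound 4 is thus estimated at 1500 nM, with a range from 600 nM to 4000 nM.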

Compound 4, half-maximal inhibitory concentration: 1120 nM
Compound 4: the middle estimate sits 1.3-fold (0.13 log units) above what was measured, within the range that was stated.
By their numbers in this assay, from the lowest: compounds 4, 3 and 2 (each within the scatter of the next). At a limit, above all of these: compound 1.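

In this assay, 3-bromobenzyl on the oxygen gives an at least 8.9-fold lower number from compound 1 to compound 4 (0.95 log units; beyond the scatter), so a third substituted benzyl in place of the (3-methoxyphenyl)carbonyl also brings the value down from the limit. Within the benzyl group, a 1.2-fold lower number from compound 3 to compound 4 (0.08 log units; within the scatter) and a 1.5-fold lower number from compound 2 to compound 4 (0.19 log units; within the scatter), so 4-fluorobenzyl, 2-methylbenzyl and 3-bromobenzyl cannot be told apart in this assay, with the substituent and its ring position both varied. Compound 1 remains at a limit of the assay, so its steps stay lower bounds: the limit of > 10000 nM in this assay, at which 1 of the 4 values shown sits.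

Open, on these data alone, is whether the carbonyl alone separates compound 1 from the benzyl compounds, which 3-methoxybenzyl on the same oxygen would test directly. Also open, as far as these compounds go, is whether this flat response holds for an amine or a carboxylic acid on the benzyl ring, or for a longer chain such as phenethyl.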